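Exchanging One Small Ring for Another on a Sulfur

The source may hold more compounds than are shown below. What is called first, only, known or untested is meant among the compounds shown, and "the series" means these compounds.

Compound 2 `Cc1ccc(-c2cs/c(=N/NC(=O)CSc3nncn3C)n2-c2ccccc2)cc1` was tested in a functional assay on C6 cells (Rattus norvegicus) for cytotoxicity, read by MTT assay, with a stated time of 24 h, tested at 12 ug/mL (on this read-out lower numbers stand for a stronger effect and higher numbers for a weaker effect at the one concentration tested), where compound 2 gives 72%. Compound 1 `Cc1nnc(SCC(=O)N/N=c2/scc(-c3ccccc3)n2-c2ccccc2)s1` gives 72.5% in this assay, a number within the scatter of compound 2, so the two cannot be told apart. Compound 3 `Cc1ccc(-c2cs/c(=N/NC(=O)CSc3nnc(C)s3)n2-c2ccccc2)cc1` is not yet measured; it differs from compound 2 in one place: 5-methyl-1,3,4-thiadiazol-2-yl in place of 4-methyl-4H-1,2,4-triazol-3-yl on a sulfur. Compound 1 already carries the entering group and gives 72.5%. The step from compound 2 to compound 3 is therefore expected to be no change at the digits printed from compound 2 to compound 3 (within the scatter), nothing beyond the scatter. For compound 3 the estimate in this assay is 72%, between 60% and 84%.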

Compound 3, a percentage reported as activity, at one concentration (the size of the read-out at that concentration, not a potency): 58.3%
Estimate against measurement, compound 3: 13.7 percentage points above; the whole stated range lies above it.
By their numbers in this assay, from the lowest: compound 3; then compounds 2 and 1 (each within the scatter of the next).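

In this assay the exchange of 4-methyl-4H-1,2,4-triazol-3-yl for 5-methyl-1,3,4-thiadiazol-2-yl gives a number 13.7 percentage points lower from compound 2 to compound 3 (beyond the scatter) and so shows that the ring on this sulfur can matter, although both rings have the same count of heavy atoms and hydrogen-bond acceptors. The thiadiazole alone does not set the number: compound 1 also carries it, and methyl in place of hydrogen on an aromatic carbon gives a number 14.2 percentage points lower from compound 1 to compound 3 (beyond the scatter) on that ring's background. Nothing here explains either step.

Going by these compounds, whether an amine or a carboxylic acid on the sulfur-bound ring would move the number further remains open. So does whether the same methyl step would appear with the triazole in place.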